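The compounds below may be only part of what the source reports. "The series", "measured", "known", "first", "only" and "open" are said of these compounds alone.

Three compounds share one core. Compound 1 `O=C(OC1(C(=O)Nc2ccc([N+](=O)[O-])cc2)CCCCC1)c1ccc(C(F)(F)F)cc1` gives 185 nM in an ADME assay on WI-38 cells (Homo sapiens) for inhibition, read by MTT assay, with a stated time of 72 h; a higher number here means a weaker inhibitor, a lower number a stronger inhibitor. Compound 2 `O=C(OC1(C(=O)Nc2ccc([N+](=O)[O-])cc2)CCCCC1)c1ccc(Br)cc1` gives 523 nM in this assay, and compound 3 `CCOC(=O)c1ccccc1C(=O)OC1(C(=O)Nc2ccc([N+](=O)[O-])cc2)CCCCC1` gives 386 nM. Compound 2 stands highest of the three numbers: the step of a 2.8-fold higher number from compound 1 to compound 2 (0.45 log units; beyond the scatter) lies beyond the scatter, while the gap between compound 2 and compound 3 lies within it, so those two cannot be ordered.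

Compound 4 `CC(=O)OC1(C(=O)Nc2ccc([N+](=O)[O-])cc2)CCCCC1` is the unmeasured member. It differs from compound 2 by methyl in place of 4-bromophenyl on a carbonyl carbon. Among the measured compounds shown here, no measured step follows that kind of change. For the measured compounds named here, the only step on record, a 2.8-fold higher number from compound 1 to compound 2 (0.45 log units; beyond the scatter), exchanges bromo for trifluoromethyl on an aromatic carbon and keeps the aromatic ring; compound 3 also keeps an aromatic ring on the carbonyl carbon. All three measured compounds therefore carry such a ring, and the move to methyl in compound 4 lies outside what they can anchor. Compound 2, the highest of the three numbers, is the starting point, and the expectation leans toward a higher number, with wide uncertainty. Compound 4 is expected to give about 1500 nM in this assay, between 400 nM and 6000 nM, which would mean an expected step of a 2.9-fold higher number from compound 2 to compound 4 (0.46 log units; beyond the scatter).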

Compound 4, half-maximal inhibitory concentration: 386 nM
Compound 4: middle estimate off by 3.9-fold (0.59 log units), on the high side; measured number outside the range, below it.
By their numbers in this assay, from the lowest: compound 1; then compounds 3, 4 and 2 (each within the scatter of the next).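

In this assay, the aromatic ring on the carbonyl carbon proves dispensable among these compounds: with a 1.4-fold lower number from compound 2 to compound 4 (0.13 log units; within the scatter) at this place, methyl and 4-bromophenyl cannot be ordered. Methyl does stand apart from 4-(trifluoromethyl)phenyl, since a 2.1-fold higher number from compound 1 to compound 4 (0.32 log units; beyond the scatter) marks a modest step, so the distinct number of compound 1 goes with that particular group and not with the presence of an aromatic ring as such, with compound 2 as the case against any such general link. Nothing shown here offers an explanation for either step.

The compounds shown leave open whether a longer chain, an amine or a carboxylic acid in place of methyl on this carbonyl carbon would keep the number in the same range. They also leave open whether a phenyl ring carrying no further group would side with compound 1 or with compound 2 and compound 4.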